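The compounds below may be only part of what the source reports. "The series", "measured", "known", "first", "only" and "open" are said of these compounds alone.

Measured so far in a functional assay on HUVEC cells (Homo sapiens), read by fluorescence and microscopy, with a stated time of 6 h, tested at 10 uM; a lower number here means a stronger effect, a higher number a weaker effect of the compound at the concentration tested:

compound 1 `COc1ccc(Nc2sc3ccccc3c2C#N)cc1` gives 57%
compound 2 `N#Cc1c(Nc2ccc(F)cc2)sc2ccccc12` gives 25%
compound 3 `CC(=O)N(c1ccc(O)cc1)c1sc2ccccc2c1C#N` gives 36%

Compound 3 stands second highest of these three numbers: compound 2 lies nearest, lower by more than the scatter, while compound 1 lies furthest, higher by more than the scatter. Compound 4 `N#Cc1c(Nc2ccc(O)cc2)sc2ccccc12` differs from compound 3 by hydrogen in place of acetyl on a nitrogen on an aromatic ring. Among the measured compounds shown here, the one measured step, a number 32 percentage points lower from compound 1 to compound 2 (beyond the scatter), concerns a group on an aromatic carbon, not this nitrogen, so it does not bear directly on the change; no step at this nitrogen has been measured. With nothing to guide a direction, the step of a number 2 percentage points higher from compound 3 to compound 4 (within the scatter) is expected to stay within the scatter. Compound 4 is therefore estimated at 38%, in a range from 18% to 60%.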

Compound 4, a percentage reported as activity, at one concentration (the size of the read-out at that concentration, not a potency): 25%
Compound 4: middle estimate off by 13 percentage points, on the high side; the measured number falls inside the stated range.
By their numbers in this assay, from the lowest: compounds 2 and 4 (each within the scatter of the next); then compound 3; then compound 1.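

In this assay, among the compounds shown here, hydrogen in place of acetyl on the nitrogen gives a first measured change at this position (a number 11 percentage points lower from compound 3 to compound 4 (beyond the scatter)). On the aromatic ring, hydroxy in place of fluoro gives no change at the digits printed from compound 2 to compound 4 (within the scatter), whereas hydrogen in place of methyl on the oxygen gives a number 32 percentage points lower from compound 1 to compound 4 (beyond the scatter), so a hydroxy group and a fluoro group read alike here, and the methoxy group of compound 1 stands apart. Nothing available explains these differences.

On these data alone, it remains open how a longer acyl chain on the nitrogen would compare with acetyl and hydrogen. As far as these compounds go, it is equally open whether an amine or a carboxylic acid on the aromatic ring would read like hydroxy and fluoro or like methoxy.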